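The compounds below may be only part of what the source reports. "The series", "measured", "known", "first", "only" and "open" are said of these compounds alone.

In a functional assay on MCF7 cells (Homo sapiens) for cytotoxicity, read by MTT assay, with a stated time of 72 h (on this read-out higher numbers stand for weaker inhibition and lower numbers for stronger inhibition), compound 1 `O=C1C(=Cc2ccc(O)cc2)C(=O)N(c2ccc(Cl)cc2)N1c1ccc(Cl)cc1`, which carries 4-hydroxyphenyl, gives 23200 nM. Compound 2 `COc1ccc(C=C2C(=O)N(c3ccc(Cl)cc3)N(c3ccc(Cl)cc3)C2=O)cc1OC`, which carries 3,4-dimethoxyphenyl at the same place on the shared core, gives > 128000 nM. That value is a limit of the assay and not a number, so compound 2 has no exact position and can only be placed at the weak end of the two results.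

Compound 3 `COc1ccccc1C=C1C(=O)N(c2ccc(Cl)cc2)N(c2ccc(Cl)cc2)C1=O` has 2-methoxyphenyl in place of 3,4-dimethoxyphenyl on a double-bonded chain carbon bound to a double-bonded ring carbon. Within the data shown here, only one measured step bears on this change: an at least 5.5-fold higher number from compound 1 to compound 2 (0.74 log units; beyond the scatter). Going by these compounds, that step lies beyond the scatter, but its true size is unknown since one end is a limit. Like compound 2, compound 3 lacks the 4-hydroxyphenyl group of compound 1, which gives 23200 nM, so a return to that level is not expected. A modest move towards a lower number is still possible, and the estimated step is an at least 2.1-fold lower number from compound 2 to compound 3 (0.32 log units; beyond the scatter). The expected value for compound 3 is 60000 nM, with an estimated range from 22000 nM to 128000 nM.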

Compound 3, half-maximal inhibitory concentration: 26300 nM
Beside the measured number, compound 3's estimate is 2.3-fold (0.36 log units) above it, within the range that was stated.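

Losing the 4-hydroxyphenyl group does not by itself cost activity at this place on the shared core: with 2-methoxyphenyl there instead, this assay shows a 1.1-fold higher number from compound 1 to compound 3 (0.05 log units; within the scatter), so the two groups cannot be told apart on this read-out. Among these compounds, until now, compound 2 was the only compound without that hydroxyl group, and the change to 2-methoxyphenyl gives an at least 4.8-fold lower number from compound 2 to compound 3 (0.68 log units; beyond the scatter), so the weak result belongs to 3,4-dimethoxyphenyl in particular and not to every methoxy-bearing group here. Compound 2 stands at a limit of the assay and not at a number, so this step has a lower bound but no known true size: the limit of > 128000 nM in this assay, at which 1 of the 3 values shown sits.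

The change from 3,4-dimethoxyphenyl to 2-methoxyphenyl alters both the number of methoxy groups and where they sit, and these compounds cannot separate the two effects. They also leave open how an amine, a carboxylic acid or a longer chain on this aromatic ring would read out in this assay.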